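Ethyl to hydrogen on the aromatic nitrogen of compound 1

This account rests on a few compounds, and the source may have more. Where it says the series, first, only, none or still open, it means among the compounds named here.

Compound 1 `CCn1cc(-c2ccnc(Nc3ccc(OC)cc3OC)n2)c2ccccc21` - 3590 nM
Compound 2 `COc1ccc(Nc2nccc(-c3sc(SC(C)C)nc3C)n2)c(OC)c1` - 5670 nM

In a functional assay on MV4-11 cells (Homo sapiens) for inhibition, read by resazurin assay, with a stated time of 72 h (a lower number here means a stronger inhibitor of growth, a higher number a weaker inhibitor of growth), compound 1 gives 3590 nM and compound 2 gives 5670 nM, so the two stand within the scatter of each other and set no order. Compound 3 `COc1ccc(Nc2nccc(-c3c[nH]c4ccccc34)n2)c(OC)c1` departs from compound 1 at one place (hydrogen in place of ethyl on an aromatic nitrogen): hydrogen in place of ethyl on an aromatic nitrogen, two ring bonds from the ring atom that bears a large group. Among the compounds with values here, no measured pair shows this change, so the data give it no size. In this assay no step beyond the scatter is expected, and neither direction is favoured. The expectation therefore stays anchored on compound 1 at 3590 nM, with a wide range. The estimated value for compound 3 is 3000 nM (expected range 1000 nM to 9000 nM).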

Compound 3, concentration for 50% growth inhibition: 600 nM
Estimate against measurement, compound 3: 5.0-fold (0.70 log units) above, outside the stated range (below it).
By their numbers in this assay, from the lowest: compound 3; then compounds 1 and 2 (each within the scatter of the next).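

In this assay, within the data shown here, the aromatic nitrogen two ring bonds from the ring atom that bears a large group proves sensitive to what it carries: hydrogen in place of ethyl gives a 6.0-fold lower number from compound 1 to compound 3 (0.78 log units; beyond the scatter), the first step that lies beyond the scatter. The ethyl group is therefore not needed at this position for growth inhibition on this core, and the unsubstituted nitrogen is the better of the two forms compared. This rests on a single pair, and nothing measured on these compounds explains the step.

From the compounds shown here alone, it remains open whether methyl or a longer chain such as propyl on this nitrogen would fall with compound 3 or with compound 1, so no trend with chain length can be drawn. An acetyl group at the same position is equally unresolved, as is whether the step carries over to other cores.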